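Swapping a dichlorophenyl ketone for a methoxyphenyl ketone

A few compounds are considered here, and "the series" means these few. Any claim that something is new, unique, unknown or untested is made for them only; others in the source may bear on it.

Of the compounds shown here, two have been tested in a functional assay on CAKI-1 cells (Homo sapiens) for cytotoxicity, read by sulforhodamine B assay, with a stated time of 48 h, tested at 10 uM; on this read-out lower numbers stand for a stronger effect and higher numbers for a weaker effect at the one concentration tested. Compound 1 `COc1ccc(-c2cc(/C=C/C(=O)c3ccc(OC)c(OC)c3)[nH]n2)cc1` gives -64% in this assay. Compound 2 `COc1cc(-c2cc(/C=C/C(=O)c3ccc(Cl)c(Cl)c3)[nH]n2)cc(OC)c1OC` gives 62% in this assay, the highest of the two numbers; the gap between it and compound 1 lies beyond the scatter, so compound 2 shows the weaker effect of the pair.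

Compound 3 `COc1ccc(C(=O)/C=C/c2cc(-c3cc(OC)c(OC)c(OC)c3)n[nH]2)cc1` has not yet been measured. It differs from compound 2 in one place: 4-methoxyphenyl in place of 3,4-dichlorophenyl on a carbonyl carbon. Compound 1, which also carries a methoxy-bearing ring on its carbonyl carbon, gave -64%, pointing toward a stronger effect than compound 2. The step of a number 57 percentage points lower from compound 2 to compound 3 (beyond the scatter) is therefore expected to be a large move toward lower numbers, well beyond the scatter. For compound 3 the expected read-out is 5%, with a plausible range from -50% to 60%.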

Compound 3, a percentage reported as activity, at one concentration (the size of the read-out at that concentration, not a potency): -17%
Beside the measured number, compound 3's estimate is 22 percentage points above it; measured number inside the range.
By their numbers in this assay, from the lowest: compound 1; then compound 3; then compound 2.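

In this assay, the group on the carbonyl carbon turns out to matter a great deal: 4-methoxyphenyl in place of 3,4-dichlorophenyl brings a number 79 percentage points lower from compound 2 to compound 3 (beyond the scatter) and so a stronger effect at the one concentration tested. For the compounds shown here, this is the first pair here that differs in one place only, which ties the shift to this single swap rather than to several differences at once. Nothing measured here explains why this swap has such a large effect.

The compounds shown leave open whether the gain comes from adding the methoxy group or from losing the two chlorines, a question that an unsubstituted phenyl on the same carbonyl carbon could help to settle. On these data alone, how a 4-dimethylaminophenyl or a 4-carboxyphenyl group would behave there also remains open.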